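The source may report more compounds than this note shows. Statements on the series, on what has been measured and on what is new or still open speak of the compounds shown alone.

Measured so far:
- compound 1, `OC(CSc1[nH]cnc2ncnc1-2)CN1CCN(C(c2ccccc2)c2ccc(Cl)cc2)CC1`: 242%
- compound 2, `CC(=O)OC(CSc1[nH]cnc2ncnc1-2)CN1CCN(C(c2ccc(F)cc2)c2ccc(F)cc2)CC1`: 248%

In a functional assay on muscle tissue (Mustela putorius furo) (a lower number here means a smaller maximal response, a higher number a larger maximal response), compound 2 gives 248%, and compound 1 gives 242%. Compound 2 stands at the top of the two numbers, but the gap to compound 1 is within the usual scatter, so the two cannot be told apart on these data. Both compounds share the same core, joined through a sulfur-bearing side chain to a piperazine that carries a diphenylmethyl group.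

Compound 3, `CC(=O)Oc1ccccc1C(=O)OC(CSc1[nH]cnc2ncnc1-2)CN1CCN(C(c2ccc(F)cc2)c2ccc(F)cc2)CC1`, has not yet been measured. It differs from compound 2 in one place: 2-acetoxyphenyl in place of methyl on a carbonyl carbon. Within the data shown here, no pair of measured compounds differs in this way, so nothing here shows how such a change moves the maximal response. For compound 3 the step of a number 8 percentage points lower from compound 2 to compound 3 (within the scatter) is therefore expected to stay within the scatter, with a wide range to allow for the unknown. The estimate for compound 3 is 240%, between 185% and 295%.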

Compound 3, largest response reached (reported as maximum), in percent of the reference or control that the assay uses: 34%
Compound 3: the middle estimate sits 206 percentage points above what was measured, and the stated range ends above it.
By their numbers in this assay, from the lowest: compound 3; then compounds 1 and 2 (each within the scatter of the next).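

With everything else in the molecule unchanged, putting 2-acetoxyphenyl in place of methyl on a carbonyl carbon in this assay gives a number 214 percentage points lower from compound 2 to compound 3 (beyond the scatter) and so shows that the maximal response depends strongly on what this position carries. The earlier compounds shown here offered no pair differing in one place, so this sensitivity could not be seen until now. Nothing measured here explains why the response falls so far with this change.

As far as these compounds go, it remains open whether the fall goes with the aromatic ring alone or also needs the acetoxy group, and a plain phenyl or a 2-hydroxyphenyl on the same carbonyl carbon would separate the two. Also open, from the compounds shown here alone, is how the response changes with a group of intermediate size there, such as an ethyl or a propyl chain.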